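This account rests on a few compounds, and the source may have more. Where it says the series, first, only, none or still open, it means among the compounds named here.

Measured compounds:
compound 1 `CCc1ccccc1-c1nc(NCc2ccc(-c3cccnc3)cc2)c2ccccc2n1`: 780 nM in an assay on a protein complex for inhibition of ubiquitin carboxyl-terminal hydrolase 1/WD repeat-containing protein 48 (Homo sapiens), read by fluorescence; a lower number here means a stronger inhibitor, a higher number a weaker inhibitor
compound 2 `Clc1ccccc1-c1nc(NCc2ccc(-c3cccnc3)cc2)c2ccccc2n1`: 2100 nM
compound 3 `Brc1ccccc1-c1nc(NCc2ccc(-c3cccnc3)cc2)c2ccccc2n1`: 1600 nM

Compound 3 gives the second highest of the three numbers. Its nearest neighbour is compound 2, and the two lie within the scatter of each other, as a 1.3-fold lower number from compound 2 to compound 3 (0.12 log units; within the scatter) shows. Compound 1 stands apart, with a 2.1-fold higher number from compound 1 to compound 3 (0.31 log units; beyond the scatter) and a 2.7-fold higher number from compound 1 to compound 2 (0.43 log units; beyond the scatter) both beyond the scatter.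

The next compound, compound 4 `c1cncc(-c2ccc(CNc3nc(N4CCCC4)nc4ccccc34)cc2)c1`, is not yet measured. It differs from compound 3 in one place: pyrrolidin-1-yl in place of 2-bromophenyl on an aromatic carbon.

Going by the values given here, none of the measured steps bears directly on this change. All three swaps so far keep the aryl group and alter only its substituent, and a move from ethyl to a halogen cost a modest amount; the exchange of bromo for chloro stayed within the scatter. Among the compounds with values here, a replacement of the whole 2-bromophenyl by pyrrolidin-1-yl has no precedent here, so the direction is open. A weakening of moderate size is taken as the working expectation, with wide uncertainty, so that the expected step is a 2.2-fold higher number from compound 3 to compound 4 (0.34 log units; beyond the scatter).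

For compound 4 the estimate is 3500 nM, expected to fall between 800 nM and 15000 nM.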

Compound 4, half-maximal inhibitory concentration: "not active" (no number reported)
No number was reported for compound 4; there is nothing to compare the estimate with.
By their numbers in this assay, from the lowest: compound 1; then compounds 3 and 2 (each within the scatter of the next).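

Going by these compounds alone, compound 4 is reported as not active in this assay with no number, so no step from compound 3 to compound 4 can be read. The compounds shown leave open whether any non-aromatic ring in place of 2-bromophenyl can give a measurable number. Nothing available here explains this result.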